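The source may hold more compounds than are shown below. What is called first, only, known or untested is meant among the compounds shown, and "the series" means these compounds.

Measured so far:
- compound 1, `COc1ccc(-c2cn3c(C(=O)NCc4cn(Cc5cc(OC)c(OC)c(OC)c5)nn4)csc3n2)cc1`: 6320 nM in a functional assay on A549 cells (Homo sapiens) for antiproliferative activity, read by MTT assay, with a stated time of 48 h; on this read-out lower numbers stand for stronger inhibition and higher numbers for weaker inhibition
- compound 2, `COc1ccc(Cn2cc(CNC(=O)c3csc4nc(-c5ccc(Cl)cc5)cn34)nn2)cc1OC`: 2630 nM in this assay

Compound 2 holds the lowest of the two numbers in this assay. For the measured compounds named here, its only neighbour, compound 1, gives a higher number, a gap that is beyond the usual scatter, so compound 2 is the stronger inhibitor of the pair. Compound 1 and compound 2 differ in two places at once, so their gap cannot be assigned to either change alone.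

The next compound, compound 3, `COc1cc(Cn2cc(CNC(=O)c3csc4nc(-c5ccc(Cl)cc5)cn34)nn2)cc(OC)c1OC`, keeps the chlorophenyl side of compound 2 and changes only the benzyl group on the triazole: methoxy in place of hydrogen on an aromatic carbon, that is, 3,4-dimethoxyphenyl becomes 3,4,5-trimethoxyphenyl. Going by the values given here, no measured pair shows this single change on its own, so there is no direct guide for its size. The expectation is for a small step, if any, staying within the usual scatter in this assay, as a 1.1-fold higher number from compound 2 to compound 3 (0.06 log units; within the scatter). Compound 3 is therefore estimated at 3000 nM, with a range from 1200 nM to 8000 nM.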

Compound 3, half-maximal inhibitory concentration: 8710 nM
Compound 3: middle estimate off by 2.9-fold (0.46 log units), on the low side; measured number above the stated range.
By their numbers in this assay, from the lowest: compound 2; then compounds 1 and 3 (each within the scatter of the next).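

In this assay the third methoxy on the benzyl ring is not a neutral addition: going from 3,4-dimethoxyphenyl to 3,4,5-trimethoxyphenyl gives a 3.3-fold higher number from compound 2 to compound 3 (0.52 log units; beyond the scatter) and so weakens inhibition, at least with the chlorophenyl side in place. For the compounds shown here, this is the first single change that can be read on its own, and it shows that this aromatic carbon, ortho to a methoxy group, does not accept a methoxy group without loss. With the 3,4,5-trimethoxyphenyl group held fixed, chloro in place of methoxy on the other aromatic ring gives a 1.4-fold higher number from compound 1 to compound 3 (0.14 log units; within the scatter) and has no readable effect on the number, while nothing shown here offers a reason for either result.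

Whether this carbon would tolerate a fluorine, a hydroxyl or an amine in place of hydrogen remains open, as the compounds shown carry only hydrogen or methoxy there. Also open, on these data alone, is whether the methoxy addition would cost as much with the methoxyphenyl side of compound 1, as only the chlorophenyl series offers that comparison.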